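Trifluoromethylphenyl urea in place of the dichlorophenyl urea

The source may hold more compounds than are shown below. What is called first, only, known or untested is meant among the compounds shown, and "the series" means these compounds.

Compound 3 `COc1cc(Cl)cc(-c2nn(-c3cccc(NC(=O)Nc4ccc(Cl)c(Cl)c4)c3)cc2-c2ccncc2)c1` gives 2400 nM in a functional assay on UACC-62 cells (Homo sapiens) for inhibition, read by sulforhodamine B assay, with a stated time of 48 h (on this read-out lower numbers stand for stronger inhibition and higher numbers for weaker inhibition), the highest number among the three compounds measured in this assay. Its nearest neighbour is compound 1 `COc1cc(Cl)cc(-c2nn(-c3cccc(NC(=O)Nc4ccc(Cl)c(C(F)(F)F)c4)c3)cc2-c2ccncc2)c1`, which in this assay gives 1270 nM; the step of a 1.9-fold higher number from compound 1 to compound 3 (0.28 log units; within the scatter) stays within the scatter. Compound 2 `COc1cc(Cl)cc(-c2nn(-c3cccc(NC(=O)Nc4cc(C(F)(F)F)cc(C(F)(F)F)c4)c3)cc2-c2ccncc2)c1` gives 360 nM in this assay, a gap to compound 3 that lies beyond the scatter. Compound 4 `COc1cc(Cl)cc(-c2nn(-c3cccc(NC(=O)Nc4cccc(C(F)(F)F)c4)c3)cc2-c2ccncc2)c1` has not been measured in this assay; it differs from compound 3 by 3-(trifluoromethyl)phenyl in place of 3,4-dichlorophenyl on an amide-type nitrogen. Among the measured compounds shown here, one measured step bears on this change: a 1.9-fold higher number from compound 1 to compound 3 (0.28 log units; within the scatter), in which a chloro replaced a trifluoromethyl without moving the number beyond the scatter. For the measured compounds named here, compound 2 carries two trifluoromethyl groups on that ring and gives a lower number than either of the others, but no single-point step connects it to the change at hand. For compound 4 the expected number in this assay is 1300 nM, estimated to fall between 450 nM and 3800 nM. The expected step is a 1.8-fold lower number from compound 3 to compound 4 (0.27 log units; within the scatter), a lower number that may still sit within the scatter.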

Compound 4, half-maximal inhibitory concentration: 1470 nM
For compound 4 the middle estimate is 1.1-fold (0.05 log units) below the measured one, and the stated range covers the measured number.
By their numbers in this assay, from the lowest: compound 2; then compounds 1, 4 and 3 (each within the scatter of the next).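

The exchange of 3,4-dichlorophenyl for 3-(trifluoromethyl)phenyl on the amide-type nitrogen gives a 1.6-fold lower number from compound 3 to compound 4 (0.21 log units; within the scatter) in this assay and so leaves this read-out unresolved between the two rings. Taking the chloro off the ring of compound 1 gives a 1.2-fold higher number from compound 1 to compound 4 (0.06 log units; within the scatter) and likewise stays within the scatter, so this ring tolerates the loss of that group with no measurable change. Hydrogen in place of one trifluoromethyl gives a 4.1-fold higher number from compound 2 to compound 4 (0.61 log units; beyond the scatter) and is the only single-place step on this ring so far that lies beyond the scatter, which singles out the second trifluoromethyl group among the changes shown.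

As far as these compounds go, whether a nitrile or a methoxy group on this ring would behave like that second trifluoromethyl group or like the chloro remains open. Nothing available here accounts for these steps.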